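The compounds below may be only part of what the source reports. "The series", "measured", "known", "first", "only" and "open" are said of these compounds alone.

The study looked at three compounds in a functional assay on HCT-116 cells (Homo sapiens) for cytotoxicity, read by MTT assay, with a stated time of 48 h; a higher number here means a weaker inhibitor, a lower number a stronger inhibitor. Compound 1, `COc1ccc(-c2nc(C(=O)/C=C\Nc3ccc(F)cc3)c3ccccn23)cc1`, gave only a limit of the assay, > 30000 nM. Compound 2, `Cc1cc2cc(N/C=C\C(=O)c3nc(-c4ccc(F)cc4)n4ccccc34)ccc2[nH]1`, likewise gave only a limit, > 30000 nM. Compound 3, `O=C(/C=C\Nc1ccc2cc[nH]c2c1)c1nc(-c2ccc(C(F)(F)F)cc2)n2ccccc12`, also gave only a limit, > 30000 nM. Compound 2 therefore stands nowhere in particular on the numbers shown: its result is a limit and not a number, and the two further values shown are limits as well, all of them resting at the limit of > 30000 nM in this assay, at which 3 of the 3 values shown sit. Within the data shown here, no step between two measured compounds is recorded, so no measured change of potency is available to build on.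

Compound 4, `O=C(/C=C\Nc1ccc(Cl)cc1)c1nc(-c2ccc(F)cc2)n2ccccc12`, is the compound still to be measured in this assay. It differs from compound 2 in one place: 4-chlorophenyl in place of 2-methyl-1H-indol-5-yl on an amine nitrogen. With every measured value resting at the same limit, the author expects the step that the limit leaves unreadable from compound 2 to compound 4 to be none beyond the scatter, and expects compound 4 most likely to return only a limit again. Her estimate for compound 4 is 50000 nM, with a range from 15000 nM to 200000 nM.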

Compound 4, half-maximal inhibitory concentration: 1210 nM
Estimate against measurement, compound 4: 41-fold (1.62 log units) above, outside the stated range (below it).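

Replacing 2-methyl-1H-indol-5-yl with 4-chlorophenyl on the amine nitrogen gives an at least 24-fold lower number from compound 2 to compound 4 (1.39 log units; beyond the scatter) in this assay, which shows that the group at this position can decide, with the rest of compound 2 unchanged, whether a compound gives a measurable value at all. Compound 2 gives > 30000 nM, which is a limit of the assay and not a number; the step therefore stands only as a minimum, and its full size cannot be read. Compound 4 is the only compound shown that gives a number rather than this limit, and its step is the first measured change of potency in the set: the limit of > 30000 nM in this assay, at which 3 of the 4 values shown sit.

Compounds 1 and 3 each differ from compound 4 in more than one place, and the single step shown cannot separate any contribution of the chlorine from that of replacing the two-ring indole with a single benzene ring. Going by these compounds, it also remains open whether an unsubstituted phenyl, a 4-bromophenyl or a pyridine ring on the same amine nitrogen would give a number like that of compound 4 or return to the limit.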